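The source may report more compounds than this note shows. Statements on the series, on what has been measured and on what is new or still open speak of the compounds shown alone.

Measured in an ADME assay on MT4 cells (Homo sapiens) for cytotoxicity, read by MTT assay, with a stated time of 96 h; a lower number here means that less compound is tolerated, a higher number that more compound is tolerated:
- compound 1 `Brc1ccc(NCc2cn(-c3ccccc3)nc2-c2ccccc2)cc1`: > 100000 nM
- compound 2 `Cc1ccc(NCc2cn(-c3ccccc3)nc2-c2ccccc2)cc1`: > 100000 nM
- compound 3 `FC(F)(F)c1ccc(NCc2cn(-c3ccccc3)nc2-c2ccccc2)cc1`: > 100000 nM

Compound 1 stands at > 100000 nM, which is a limit and not a number. It is not alone there, for the series shows (the limit of > 100000 nM in this assay, at which 3 of the 3 values shown sit).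

Compound 4 `FC(F)(F)c1ccc(-c2nn(-c3ccccc3)cc2CNc2ccc(Br)cc2)cc1` keeps the core of compound 1 and adds one group: trifluoromethyl in place of hydrogen on an aromatic carbon. The change is phenyl to 4-(trifluoromethyl)phenyl.

Three measured steps come closest, though none is this same change. They are a step that the two limits leave unreadable from compound 1 to compound 2, a step that the two limits leave unreadable from compound 1 to compound 3 and a step that the two limits leave unreadable from compound 2 to compound 3. None gives a size, so the direction in this assay cannot be read from them. Compound 3 also carries a trifluoromethyl group, and its value of > 100000 nM is a limit too.

No step beyond the usual scatter is therefore expected, and compound 4 will most likely report the same limit. The estimated step is a number no higher from compound 1 to compound 4 (the limit leaves the size open). Compound 4 is expected near 100000 nM, within an estimated range of 40000 nM to 150000 nM.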

Compound 4, half-maximal cytotoxic concentration: > 100000 nM
Compound 4 gave a limit, no number; the forecaster's own chance of this, stated with the estimate: 75%; the middle value sits exactly at the limit.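

Among these compounds, compound 4, like compound 1, gives only a limit in this assay, so no step between compound 1 and compound 4 can be read. The compounds shown leave open what half-maximal cytotoxic concentration any of them actually has, because all stand at the same limit: the limit of > 100000 nM in this assay, at which 4 of the 4 values shown sit.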